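The source may report more compounds than this note shows. Statements on the series, on what has been measured and on what is new or still open speak of the compounds shown alone.

Two measured compounds set the scene. Compound 1 `Cc1c(C(=O)Nc2c(F)cc(-c3cccc(F)c3)cc2F)nc2ccc(C(F)(F)F)cc2c1O` gives 1.28% in a functional assay on A-375 cells (Homo sapiens) for antiproliferative activity, read by MTT assay, with a stated time of 24 h, tested at 0.02 ug/mL (on this read-out lower numbers stand for a weaker effect and higher numbers for a stronger effect at the one concentration tested), and compound 2 `COc1ccc2nc(C(=O)Nc3ccc(-c4ccccc4)cc3)c(C)c(O)c2c1` gives 0.56% in this assay. Compound 2 stands at the lower end of these two numbers, yet its gap to compound 1 lies within the scatter, so both read as near-zero effects. Compound 3 `Cc1c(C(=O)Nc2ccc(-c3ccccc3)cc2)nc2ccccc2c1O` differs from compound 2 in one place: hydrogen in place of methoxy on an aromatic carbon. Going by the values given here, no measured pair shows what this change does. Both measured numbers sit near zero, and the step of a number 0.9 percentage points higher from compound 2 to compound 3 (within the scatter) is expected to be small, none beyond the scatter. Compound 3 is expected to give about 1.5%, between 0% and 10%.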

Compound 3, a percentage reported as inhibition, at one concentration (the size of the read-out at that concentration, not a potency): 0.06%
Estimate against measurement, compound 3: 1.4 percentage points above; measured number inside the range.
By their numbers in this assay, from the lowest: compounds 3, 2 and 1 (each within the scatter of the next).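

Going by these compounds alone, the step of a number 0.5 percentage points lower from compound 2 to compound 3 (within the scatter) in this assay is the first direct reading of hydrogen in place of methoxy on this aromatic carbon. At this one concentration, the change shows no effect beyond the scatter, but both compounds read near zero, so any contribution of the methoxy group could remain hidden. No available evidence bears on this result. On these data alone, whether an amine or a carboxylic acid on this carbon would give a clearly larger read-out stays open, as does the effect of the same change at higher concentrations.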